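This account rests on a few compounds, and the source may have more. Where it says the series, first, only, none or still open, it means among the compounds named here.

Measured compounds:
Compound 1, `O=C(O)Cc1sc(C(c2ccccc2)c2ccc(F)cc2)nc1-c1ccc(Cl)cc1`; in an in vitro assay on HEK385-7 cells for displacement of a labelled ligand from prostaglandin D2 receptor 2 (Homo sapiens) (a lower number here means a stronger inhibitor, a higher number a weaker inhibitor), compound 1 gives 17 nM.
Compound 2, `COc1ccc(C(c2ccccn2)c2nc(-c3ccc(Cl)cc3)c(CC(=O)O)s2)cc1`; in this assay compound 2 gives 61 nM.
Compound 3, `O=C(O)Cc1sc(C(c2ccccc2)c2ccccc2)nc1-c1ccc(F)cc1`; in this assay compound 3 gives 8.7 nM.

Compound 3 carries the lowest of the three numbers in this assay. Within the data shown here, its nearest neighbour is compound 1, whose number lies within the usual scatter of the one for compound 3, so no order between those two can be read from the data. Compound 2 stands furthest away, beyond the scatter, and its number is the highest of the three.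

The next compound, compound 4, `O=C(O)Cc1sc(C(c2ccccc2)c2ccccc2)nc1-c1ccc(C(F)(F)F)cc1`, differs from compound 3 in one place: trifluoromethyl in place of fluoro on an aromatic carbon, which, read one bond further out, turns 4-fluorophenyl into 4-(trifluoromethyl)phenyl. Among the measured compounds shown here, no pair of measured compounds shows this change, so its effect in this assay cannot be taken from a known step. Among the measured compounds, substituents on this ring vary only between fluoro and chloro, and those two compounds sit within the scatter of each other. The step from compound 3 to compound 4 is therefore expected to be small, a 1.7-fold higher number from compound 3 to compound 4 (0.24 log units; within the scatter), with a slight lean toward a higher number but nothing clearly beyond the scatter. For compound 4 the estimate in this assay is 15 nM, with a range from 4 nM to 60 nM.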

Compound 4, half-maximal inhibitory concentration: 1100 nM
Estimate against measurement, compound 4: 73-fold (1.87 log units) below, and the stated range ends below it.
By their numbers in this assay, from the lowest: compounds 3 and 1 (each within the scatter of the next); then compound 2; then compound 4.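

In this assay, putting trifluoromethyl in place of fluoro on this aromatic carbon, para to a large group, gives a 130-fold higher number from compound 3 to compound 4 (2.10 log units; beyond the scatter), the first step read at this position and one well beyond the scatter. The earlier compounds shown here carried only fluoro or chloro on this ring and offered no single-place step there, whereas this result shows that the number at this position can respond very strongly to the group it carries. Nothing measured here gives a reason for the size of this step.

The compounds shown leave open how other groups at this place, such as methyl, methoxy or a nitrile, would read in this assay. They also leave open whether the same exchange would give a step of similar size on the core of compound 2.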